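The compounds below may be only part of what the source reports. "The series", "measured", "known", "first", "only" and "open" are said of these compounds alone.

Measured so far in a functional assay on MCF7 cells (Homo sapiens) for antiproliferative activity, read by MTT assay, with a stated time of 48 h; a lower number here means a stronger inhibitor, a higher number a weaker inhibitor:
Compound 1 `CC(C)=CCC[C@]1(C)/C=C/[C@@H](OC(=O)C=C(C)C)[C@](C)(O)/C=C/C(=O)/C(CF)=C\C1` gives 240 nM.
Compound 2 `CC(=O)OC/C1=C/C[C@](C)(CCC=C(C)C)/C=C/[C@@H](OC(=O)C=C(C)C)[C@](C)(O)/C=C/C1=O` gives 4510 nM.
Compound 3 `CC(C)=CCC[C@]1(C)/C=C/[C@@H](OC(=O)C=C(C)C)[C@](C)(O)/C=C/C(=O)/C(CN=[N+]=[N-])=C\C1` gives 4890 nM.

On these numbers compound 2 stands second highest of the three; compound 3 sits within the scatter of it, while compound 1 is far lower. The two large steps both leave compound 1: a 19-fold higher number from compound 1 to compound 2 (1.27 log units; beyond the scatter) and a 20-fold higher number from compound 1 to compound 3 (1.31 log units; beyond the scatter). Between the two weaker compounds the step is small, a 1.1-fold higher number from compound 2 to compound 3 (0.04 log units; within the scatter).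

Compound 4 `CSC(=S)OC/C1=C/C[C@](C)(CCC=C(C)C)/C=C/[C@@H](OC(=O)C=C(C)C)[C@](C)(O)/C=C/C1=O` differs from compound 2 by a group of 4 heavy atoms (2 carbon, 2 sulfur; no ring) in place of a group of 3 heavy atoms (2 carbon, 1 oxygen; no ring), on an oxygen on a saturated carbon. For the measured compounds named here, no measured step exchanges one group on that oxygen for another; the only comparison at this end of the molecule, between compound 2 and compound 3, stayed within the scatter. Compound 4 is therefore expected to sit close to compound 2, with an expected step of a 1.1-fold higher number from compound 2 to compound 4 (0.04 log units; within the scatter). The estimate for compound 4 is 5000 nM, ranging from 2000 nM to 12500 nM.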

Compound 4, half-maximal inhibitory concentration: 900 nM
For compound 4 the middle estimate is 5.6-fold (0.74 log units) above the measured one; the whole stated range lies above it.
By their numbers in this assay, from the lowest: compound 1; then compound 4; then compounds 2 and 3 (each within the scatter of the next).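

Exchanging the acetyl on this oxygen for the sulfur-bearing group moves the number beyond the scatter (a 5.0-fold lower number from compound 2 to compound 4 (0.70 log units; beyond the scatter)), so the close agreement of compound 2 and compound 3 did not mean that this end of the molecule tolerates every change. The sulfur-bearing group also gives a lower number than azido (a 5.4-fold lower number from compound 3 to compound 4 (0.74 log units; beyond the scatter)), but a higher one than fluoro (a 3.8-fold higher number from compound 1 to compound 4 (0.57 log units; beyond the scatter)). No available evidence explains these differences. On these data alone, whether a hydroxyl, an amine or a chlorine atom on this saturated chain carbon would give a number nearer that of compound 1 remains open.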